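The compounds below may be only part of what the source reports. "The series", "measured", "known", "first", "only" and "open" are said of these compounds alone.

Compound 1 `CCCCCCCCCCCCCCCCCC(=O)O[C@H]1[C@H](O)[C@H](n2ccc(N)nc2=O)O[C@@H]1CO` carries a long saturated ester chain on the shared core. In a functional assay on HeLa cells (Homo sapiens) for cytotoxicity, read by cell counting, with a stated time of 48 h (on this read-out higher numbers stand for an effect only at larger amounts of compound and lower numbers for an effect already at smaller amounts), compound 1 gives 0.13 ug/mL, the highest number among the three compounds measured. Compound 2 `CCCCCC(=O)O[C@H]1[C@H](O)[C@H](n2ccc(N)nc2=O)O[C@@H]1CO` bears a much shorter chain, and in this assay compound 2 gives 0.05 ug/mL. Compound 3 `CCCCCCCC/C=C\CCCCCCCC(=O)O[C@H]1[C@H](O)[C@H](n2ccc(N)nc2=O)O[C@@H]1CO` keeps the chain length of compound 1 but carries a double bond, and in this assay compound 3 gives 0.06 ug/mL. The step of a 2.6-fold lower number from compound 1 to compound 2 (0.41 log units; beyond the scatter) and the step of a 2.2-fold lower number from compound 1 to compound 3 (0.34 log units; beyond the scatter) both run downward and both lie beyond the scatter, whereas a 1.2-fold higher number from compound 2 to compound 3 (0.08 log units; within the scatter) stays within it.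

Compound 4 `CCCCCCCCCCCCCCCCCCCCCC(=O)O[C@H]1[C@H](O)[C@H](n2ccc(N)nc2=O)O[C@@H]1CO` extends the chain of compound 1: butyl in place of hydrogen on a saturated chain carbon, ten or more bonds along the chain from a carbonyl carbon. For the measured compounds named here, no measured step adds saturated length at this place. The two steps that touch the chain, from compound 1 to compound 2 and from compound 1 to compound 3, each took saturated length away or inserted a double bond, and each lowered the number. Going the other way, a further lengthening is expected to leave the number where it is or raise it slightly. Compound 4 is therefore estimated at 0.18 ug/mL, with a range from 0.08 ug/mL to 0.4 ug/mL. The expected step of a 1.4-fold higher number from compound 1 to compound 4 (0.14 log units; within the scatter) is small and may not clear the scatter.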

Compound 4, concentration for half-maximal effect: 1.1 ug/mL
Compound 4: middle estimate off by 6.1-fold (0.79 log units), on the low side; the measured number lies above the stated range.
By their numbers in this assay, from the lowest: compounds 2 and 3 (each within the scatter of the next); then compound 1; then compound 4.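

Butyl in place of hydrogen on a saturated chain carbon is the first change here to raise the number beyond the scatter, giving in this assay an 8.5-fold higher number from compound 1 to compound 4 (0.93 log units; beyond the scatter) and so showing that this far stretch of the saturated chain is not a silent place. Read beside a 2.6-fold lower number from compound 1 to compound 2 (0.41 log units; beyond the scatter), this gives a single direction across compounds 2, 1 and 4, with the number rising as saturated length grows, while compound 3 goes against any account built on length alone, since it keeps the chain length of compound 1 and still shows a 2.2-fold lower number from compound 1 to compound 3 (0.34 log units; beyond the scatter). Nothing available here explains why the added butyl raises the number.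

The three saturated compounds leave open whether the number keeps rising with a longer chain, or whether it climbs gradually or sharply at lengths lying between those of compound 1 and compound 4. They also leave open whether a double bond in the chain of compound 4 would bring the number down as it does in compound 3, and how an amine or a carboxylic acid at the far end of the chain would read.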